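The source may hold more compounds than are shown below. What is called first, only, known or untested is meant among the compounds shown, and "the series" means these compounds.

Measured so far in an ADME assay (liver) for metabolic stability, with Liver microsome (Homo sapiens) as the target, read by LC-MS, using microsomes, with a stated time of 30 min, tested at 4 uM; a lower number here means that less of the compound is left, a higher number that more of the compound is left
compound 1 `Cc1nc(N2CCN(C)CC2)c2nc(-c3ccccc3C(F)(F)F)n(C3CCOCC3)c2n1` gives 24%
compound 2 `Cc1nc(N2CCN(C)CC2)c2nc(-c3cccc(C(F)(F)F)c3)n(C3CCOCC3)c2n1` gives 19%

Among the measured compounds shown here, only two compounds have been measured, so there is little to place compound 2 against. In this assay compound 2 gives 19% and compound 1 gives 24%, two values within the usual scatter of each other.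

The next compound is compound 3 `COc1ccccc1-c1nc2c(N3CCN(C)CC3)nc(C)nc2n1C1CCOCC1`, which puts 2-methoxyphenyl in place of 3-(trifluoromethyl)phenyl on an aromatic carbon, with the rest of the molecule unchanged. The counted difference is 2-methoxyphenyl in place of 3-(trifluoromethyl)phenyl on an aromatic carbon.

For the measured compounds named here, one measured step bears on this change, and only indirectly. It is a number 5 percentage points lower from compound 1 to compound 2 (within the scatter), which exchanges 2-(trifluoromethyl)phenyl for 3-(trifluoromethyl)phenyl at the same place. That step shows that this exchange did not move the number beyond the scatter. Going by the values given here, no measured compound carries 2-methoxyphenyl, however, so the new group itself is untested and the range has to stay wide. With no evidence for a direction, the expected step is a number 2 percentage points higher from compound 2 to compound 3 (within the scatter), which means no real change is expected. Compound 3 is estimated at 21%, with an expected range from 8% to 38%.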

Compound 3, percent of the compound remaining: 22%
Compound 3: middle estimate off by 1 percentage points, on the low side; measured number inside the range.
By their numbers in this assay, from the lowest: compounds 2, 3 and 1 (each within the scatter of the next).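

In this assay, putting 2-methoxyphenyl in place of 3-(trifluoromethyl)phenyl gives a number 3 percentage points higher from compound 2 to compound 3 (within the scatter), and methoxy in place of trifluoromethyl, with the group kept at the same place on the phenyl ring, gives a number 2 percentage points lower from compound 1 to compound 3 (within the scatter). The earlier compounds shown here varied only where a trifluoromethyl group sat on the phenyl ring, whereas these steps exchange that group for a different one, which brings oxygen and a hydrogen-bond acceptor, and neither step goes beyond the scatter, so across these three compounds the read-out does not respond to the exchange. Nothing measured here speaks to why the number holds, or to which part of the molecule is lost in the microsomes.

Going by these compounds, what stays open is whether anything at this place can move the number beyond the scatter, for instance a phenyl ring carrying an amine or a carboxylic acid, or a pyridine ring in place of phenyl. On these data alone, it is also open whether 3-methoxyphenyl would match 2-methoxyphenyl, and whether changing the oxan-4-yl group would matter more than any change at this place.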